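The source may report more compounds than this note shows. Statements on the series, on what has been measured and on what is new or still open speak of the compounds shown alone.

Measured so far:
- compound 2 `COc1cccc(/C=C/C(=O)c2c(OC)cc(OC)cc2OC)c1`: 0.3%
- compound 1 `COc1cc(O)c(C(=O)/C=C/c2ccc(F)cc2)c(OC)c1`: "not active" (no number reported)
- compound 3 `COc1cc(O)c(C(=O)/C=C/c2ccccc2OC)c(OC)c1`: "not active" (no number reported)

Among the compounds with values here, in a functional assay on Huh-7 cells (Homo sapiens), read by fluorescence and BrdU incorporation, with a stated time of 48 h, tested at 25 uM (on this read-out higher numbers stand for a weaker effect at the one concentration tested and lower numbers for a stronger effect), compound 2 is the only compound with a number; compound 1 and compound 3 are each reported without one. Compound 4 `COc1cc(OC)c(C(=O)/C=C/c2ccc(F)cc2)c(OC)c1` has not yet been tested in this assay. It differs from compound 2 in one place: 4-fluorophenyl in place of 3-methoxyphenyl on a double-bonded chain carbon bound to a double-bonded chain carbon. Within the data shown here, no measured pair shows what such a change does, so there is no step to lean on. Compound 1 carries the same 4-fluorophenyl on a different core and gives "not active" (no number reported) in this assay, which makes a weakening plausible. For compound 4 the expected value in this assay is 8%, in a range from 0% to 45%. The expected step of a number 7.7 percentage points higher from compound 2 to compound 4 (within the scatter) is toward a weaker effect, with wide uncertainty.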

Compound 4, a percentage reported as activity, at one concentration (the size of the read-out at that concentration, not a potency): 1.1%
For compound 4 the middle estimate is 6.9 percentage points above the measured one, within the range that was stated.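

In this assay, replacing 3-methoxyphenyl with 4-fluorophenyl gives a number 0.8 percentage points higher from compound 2 to compound 4 (within the scatter). Within the data shown here, this is the first readable step at this position, and it shows that the read-out does not separate these two groups on this core. Compound 1 carries the same 4-fluorophenyl on a different core but has no number, so no step involving it can be read, and no measurement here offers an explanation for the result. Going by these compounds, it remains open whether a 4-aminophenyl group or a benzoic acid group at this position would also leave the read-out unchanged.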